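Moving the Methyl on the Thiazole of a Hydroxamate

A few compounds are considered here, and "the series" means these few. Any claim that something is new, unique, unknown or untested is made for them only; others in the source may bear on it.

Measured so far:
compound 1, `CC(C)(NC(=O)c1nc(-c2nccs2)sc1C1CC1)c1ccc(C(=O)NO)cc1`: 148 nM
compound 2, `Cc1csc(-c2nc(C(=O)N[C@@H](C)c3ccc(C(=O)NO)cc3)c(C3CC3)s2)n1`: 19.1 nM

Both compounds were tested in an assay on cells for inhibition of protein deacetylase HDAC6 (Homo sapiens), read by fluorescence, with a stated time of 24 h; a lower number here means a stronger inhibitor, a higher number a weaker inhibitor. Compound 2 has the lowest of the two numbers recorded. Compound 1 gives 148 nM, which sits well above the value of compound 2 and beyond the usual scatter, although compound 1 also differs from compound 2 in more than one place, so the two values alone do not single out any one feature as the reason.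

Compound 3, `Cc1cnc(-c2nc(C(=O)N[C@@H](C)c3ccc(C(=O)NO)cc3)c(C3CC3)s2)s1`, has not yet been measured. It keeps every atom of compound 2 and changes only the arrangement of one ring: 5-methyl-1,3-thiazol-2-yl in place of 4-methyl-1,3-thiazol-2-yl on an aromatic carbon. Within the data shown here, no measured pair in this set shows what such a shift of a methyl group does, so the expectation rests on the general observation that small rearrangements of this kind usually move the number little. The step of a 1.3-fold higher number from compound 2 to compound 3 (0.12 log units; within the scatter) is therefore expected to stay within the scatter, in no particular direction. Compound 3 is estimated at 25 nM, with a plausible range from 8 nM to 80 nM in this assay.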

Compound 3, half-maximal inhibitory concentration: 18.5 nM
Estimate against measurement, compound 3: 1.4-fold (0.13 log units) above, and the stated range covers the measured number.
By their numbers in this assay, from the lowest: compounds 3 and 2 (each within the scatter of the next); then compound 1.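

In this assay, among these compounds, this pair gives the first view of a change in a single place: a 1.0-fold lower number from compound 2 to compound 3 (0.01 log units; within the scatter). Moving the methyl group, so that 5-methyl-1,3-thiazol-2-yl stands in place of 4-methyl-1,3-thiazol-2-yl, therefore leaves the number within the usual scatter, which means that, at this position and in this assay, the two arrangements of the ring cannot be told apart. Nothing measured here offers a reason for this result.

The compounds shown leave open whether the methyl group matters at all, since the pair only moves it around the ring and never removes it while keeping the rest of compound 2 intact. They also leave open what happens when a larger or different group takes its place on the same ring, such as an ethyl group, a methoxy group, an amine or a carboxylic acid, so the tolerance seen for this one shift cannot be extended to other changes at this position.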